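This account rests on a few compounds, and the source may have more. Where it says the series, first, only, none or still open, it means among the compounds named here.

Compound 1 `COc1ccc(-c2nc3sc(-c4ccccc4)cn3n2)cc1`: 71%
Compound 2 `Clc1ccc(-c2cn3nc(-c4ccccc4)nc3s2)cc1`: 15%
Compound 3 `COc1ccc(-c2nc3sc(-c4ccc(Cl)cc4)cn3n2)cc1`: 9%

All three values come from a functional assay on M14 cells (Homo sapiens) for inhibition, read by sulforhodamine B assay, with a stated time of 48 h, tested at 10 uM; a higher number here means more inhibition of growth at the concentration tested, a lower number less inhibition of growth. Compound 2 sits low on these numbers. The step of a number 6 percentage points lower from compound 2 to compound 3 (within the scatter) lies within the scatter, so those two cannot be ordered, while compound 1 stands far higher at 71%.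

Not yet measured is compound 4 `c1ccc(-c2nc3sc(-c4ccccc4)cn3n2)cc1`, which differs from compound 2 as follows: hydrogen in place of chloro on an aromatic carbon. This is hydrogen in place of chloro on an aromatic carbon.

The closest measured precedent is the same exchange in the opposite direction. The step of a number 62 percentage points lower from compound 1 to compound 3 (beyond the scatter), chloro in place of hydrogen on an aromatic carbon, is large and beyond the scatter. Read in reverse, it suggests a large rise when chloro leaves compound 2. The step of a number 6 percentage points lower from compound 2 to compound 3 (within the scatter), methoxy in place of hydrogen on an aromatic carbon, shows no change beyond the scatter in the chloro-bearing pair. Within the data shown here, no measurement shows what methoxy does in the absence of chloro, and only one chloro exchange has been measured, so the range stays wide.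

A large upward move in this assay is expected, estimated as a number 47 percentage points higher from compound 2 to compound 4 (beyond the scatter). For compound 4 the estimated value is 62%, with an expected range from 32% to 85%.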

Compound 4, percent growth inhibition at one concentration: 13%
Estimate against measurement, compound 4: 49 percentage points above, and the stated range ends above it.
By their numbers in this assay, from the lowest: compounds 3, 4 and 2 (each within the scatter of the next); then compound 1.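

In this assay, the change from 4-chlorophenyl to phenyl, taken without methoxy present, gives a number 2 percentage points lower from compound 2 to compound 4 (within the scatter), so the chloro exchange that was so costly on the methoxy-bearing core has no effect that can be read on this one: the same change on two cores in this assay, a number 62 percentage points lower (beyond the scatter) from compound 1 to compound 3 and a number 2 percentage points higher (within the scatter) from compound 4 to compound 2, 64 percentage points apart, beyond the scatter of two such steps

The methoxy group likewise shows its effect only in the absence of chloro, where hydrogen in its place gives a number 58 percentage points lower from compound 1 to compound 4 (beyond the scatter), although it showed no effect beyond the scatter when chloro was present: the same change on two cores in this assay, a number 6 percentage points lower (within the scatter) from compound 2 to compound 3 and a number 58 percentage points higher (beyond the scatter) from compound 4 to compound 1, 64 percentage points apart, beyond the scatter of two such steps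

The two changes therefore cannot be read as separate contributions, and among these four compounds only the combination of methoxy with no chloro, in compound 1 at 71%, stands apart from the rest.

The compounds shown leave open whether the high value of compound 1 depends on methoxy itself or would also appear with an ethoxy or hydroxy group in its place. They also leave open whether a fluoro group or an amine, in the place held by chloro, would keep or lose that value alongside methoxy.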